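Replacing the triazolylmethyl arm of compound 2

A few compounds are considered here, and "the series" means these few. Any claim that something is new, unique, unknown or untested is made for them only; others in the source may bear on it.

Measured compounds:
- compound 1, `CCC(CC)(c1nnc[nH]1)c1ccc(-c2ccc3cc(F)cc(F)c3c2)[nH]c1=O`, 89 nM
- compound 2, `CC(C)C(Cc1nnc[nH]1)c1ccc(-c2ccc3cccc(F)c3c2)[nH]c1=O`, 10 nM
- compound 3, `CCn1ncc2c(F)cc(-c3ccc(C(CC)(CC)c4nnc(C)[nH]4)c(=O)[nH]3)cc21`, 34 nM

All three compounds share a core and were tested in an assay on CHO cells for displacement of a labelled ligand from prostaglandin E2 receptor EP3 subtype (Homo sapiens), read by radioligand binding; a higher number here means a weaker inhibitor, a lower number a stronger inhibitor. Compound 2 gives 10 nM and stands at the lowest number of the three, so it is the strongest inhibitor here: compound 3 sits a step above it that is beyond the scatter, and compound 1 sits further above still, also beyond the scatter.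

Compound 4, `CC(C)C(c1noc(=O)[nH]1)c1ccc(-c2ccc3cccc(F)c3c2)[nH]c1=O`, has not yet been measured in this assay. It differs from compound 2 in one place: a group of 6 heavy atoms (2 carbon, 2 nitrogen, 2 oxygen; one five-membered aromatic ring with 3 hetero atoms) in place of a group of 6 heavy atoms (3 carbon, 3 nitrogen; one five-membered aromatic ring with 3 hetero atoms), on a saturated chain carbon bound to an aromatic carbon and a saturated chain carbon. In words, a ring carrying two oxygens and a non-aromatic double bond now sits where the (4H-1,2,4-triazol-3-yl)methyl group did, directly on the saturated chain carbon.

Within the data shown here, no measured pair shows this exact change, so the direction rests on judgement alone. Compound 4 is expected to land at a somewhat higher number than compound 2, a step of a 2.5-fold higher number from compound 2 to compound 4 (0.40 log units; beyond the scatter) in this assay, modest and close to the edge of the scatter. The estimate for compound 4 is 25 nM, with a range from 6 nM to 100 nM.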

Compound 4, inhibition constant: 15 nM
Compound 4: middle estimate off by 1.7-fold (0.22 log units), on the high side; measured number inside the range.
By their numbers in this assay, from the lowest: compounds 2 and 4 (each within the scatter of the next); then compound 3; then compound 1.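

In this assay, replacing the (4H-1,2,4-triazol-3-yl)methyl group with the ring carrying two oxygens gives a 1.5-fold higher number from compound 2 to compound 4 (0.18 log units; within the scatter), so the two compounds cannot be told apart. Among these compounds, this is the first single-place comparison in the set, since compounds 1, 2 and 3 differ from each other in more than one place, and it shows that this saturated chain carbon can carry either group without a step beyond the scatter. Nothing measured here explains why the two numbers stay so close.

As far as these compounds go, the change swaps the ring and removes the methyl link in one step, so the share of each remains open. Also open, from the compounds shown here alone, is whether a carboxylic acid or a tetrazole on the same saturated chain carbon would give a similar number.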